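A Second Methyl Group: From Compound 3 to Compound 4

This account rests on a few compounds, and the source may have more. Where it says the series, first, only, none or still open, it means among the compounds named here.

Compound 1 `Brc1ccccc1Nc1nc2cccnc2[se]1` gives 185000 nM in a functional assay on MCF7 cells (Homo sapiens) for cytotoxicity, read by MTT assay, with a stated time of 72 h; a higher number here means a weaker inhibitor, a lower number a stronger inhibitor.
Compound 2 `Cc1ccccc1Nc1nc2cccnc2[se]1` gives 52500 nM in this assay.
Compound 3 `Cc1cccc(Nc2nc3cccnc3[se]2)c1` gives 56400 nM in this assay.

Of these three numbers, compound 3 holds the second highest; compound 2 sits within the scatter of it, while compound 1 lies beyond. Compound 4 `Cc1ccc(Nc2nc3cccnc3[se]2)cc1C` differs from compound 3 by methyl in place of hydrogen on an aromatic carbon. Among the compounds with values here, the only measured step, a 3.5-fold lower number from compound 1 to compound 2 (0.55 log units; beyond the scatter), exchanges one group for another rather than adding a methyl, so it bears only loosely here. Compounds 2 and 3 show that a single methyl at either of two places gives numbers within the scatter of each other. No step beyond the scatter is therefore expected, a 1.3-fold lower number from compound 3 to compound 4 (0.10 log units; within the scatter). Compound 4 is estimated at 45000 nM, between 18000 nM and 110000 nM.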

Compound 4, half-maximal inhibitory concentration: 202000 nM
Compound 4: the middle estimate sits 4.5-fold (0.65 log units) below what was measured, outside the stated range (above it).
By their numbers in this assay, from the lowest: compounds 2 and 3 (each within the scatter of the next); then compounds 1 and 4 (each within the scatter of the next).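

Adding one methyl, ortho to a methyl group and para to a large group, gives a 3.6-fold higher number from compound 3 to compound 4 (0.55 log units; beyond the scatter) in this assay. Even a single added carbon on this aromatic ring can therefore weaken the compound, which compounds 2 and 3, each carrying one methyl, did not reveal. No measurement offered here explains this loss. Still open, going by these compounds, is whether a methyl at this place would have the same effect without the methyl already present. Also open, on these data alone, is how an ethyl, a methoxy or an amine would behave there.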